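Changing the Acyl Arm: From Compound 3 to Compound 4

This account rests on a few compounds, and the source may have more. Where it says the series, first, only, none or still open, it means among the compounds named here.

Compound 1 `CC(C)C[C@H](N)c1cc(C(F)(F)F)ccc1N1CCN(C(=O)CSc2ccc(Cl)cc2Cl)CC1`: 1500 nM
Compound 2 `COc1ccc(CC(C)C(=O)N2CCN(c3ccc(C(F)(F)F)cc3[C@@H](N)CC(C)C)CC2)cc1`: 120 nM
Compound 3 `CC(C)C[C@H](N)c1cc(C(F)(F)F)ccc1N1CCN(C(=O)COc2ccc3ccccc3c2)CC1`: 2000 nM

In an assay on HEK293 cells for displacement of a labelled ligand from Melanocortin receptor 4 (Homo sapiens) (on this read-out higher numbers stand for weaker inhibition and lower numbers for stronger inhibition), compound 3 stands close to compound 1, the two numbers lying within the usual scatter a 1.3-fold higher number from compound 1 to compound 3 (0.12 log units; within the scatter), while compound 2 sits well apart a 17-fold higher number from compound 2 to compound 3 (1.22 log units; beyond the scatter). Compound 4 `CC(C)C[C@H](N)c1cc(C(F)(F)F)ccc1N1CCN(C(=O)CCNC2CCCCC2)CC1` keeps the shared core and differs from compound 3 only in the acyl arm: (cyclohexylamino)methyl in place of (naphthalen-2-yl)oxy on a saturated chain carbon bound to a carbonyl carbon.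

Among the compounds with values here, two measured steps touch this arm. The step from compound 1 to compound 3 exchanges one aromatic group for another and changes little. The step from compound 2 to compound 3 shows that a different arm can move the number a great deal. Neither step introduces anything like a (cyclohexylamino)methyl group, so there is no direct guide for compound 4. The expectation is therefore a number near that of compound 3, with wide uncertainty in either direction, and compound 4 is estimated at 1500 nM (range 300 nM to 7000 nM), a step of a 1.3-fold lower number from compound 3 to compound 4 (0.12 log units; within the scatter).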

Compound 4, inhibition constant: 4800 nM
Beside the measured number, compound 4's estimate is 3.2-fold (0.51 log units) below it; measured number inside the range.
By their numbers in this assay, from the lowest: compound 2; then compounds 1 and 3 (each within the scatter of the next); then compound 4.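

In this assay, within the data shown here, this is the first change at this saturated chain carbon to move the number beyond the scatter: putting (cyclohexylamino)methyl in place of the aromatic arms gives weaker inhibition in both comparisons (a 2.4-fold higher number from compound 3 to compound 4 (0.38 log units; beyond the scatter)) and (a 3.2-fold higher number from compound 1 to compound 4 (0.51 log units; beyond the scatter)), where the earlier swap of one aromatic arm for another did not shift the number beyond the scatter. Both steps are modest, and the 1-(4-methoxybenzyl)ethyl arm remains far ahead (a 40-fold higher number from compound 2 to compound 4 (1.60 log units; beyond the scatter)). None of the data shown explains why the number moves.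

The naphthalen-2-yl rings leave and the amine nitrogen enters in a single step, so the compounds shown cannot separate these two changes. A cyclohexyloxy arm, which keeps the cyclohexyl ring but carries an oxygen in place of the amine nitrogen, would help to tell them apart.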